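The source may hold more compounds than are shown below. What is called first, only, known or untested is meant among the compounds shown, and "the series" means these compounds.

Of the compounds shown here, three have been measured in a functional assay on MCF7 cells (Homo sapiens) for antiproliferative activity, read by MTT assay, with a stated time of 72 h; on this read-out higher numbers stand for weaker inhibition and lower numbers for stronger inhibition. Compound 1 `COc1cc(-n2cnc3ccc(-c4ccc([N+](=O)[O-])cc4)cc32)cc(OC)c1OC` gives 740 nM. Compound 2 `COc1cc(-n2cnc3ccc(-c4cccc(Cl)c4)cc32)cc(OC)c1OC` gives 3120 nM, and among the two numbers reported it stands highest, with compound 1 nearest at a 4.2-fold higher number from compound 1 to compound 2 (0.62 log units; beyond the scatter). Compound 3 `COc1cc(-c2ccc3ncn(-c4cc(OC)c(OC)c(OC)c4)c3c2)cc(OC)c1OC` gives only the assay limit of > 10000 nM, a boundary rather than a number, as noted by the limit of > 10000 nM in this assay, at which 1 of the 3 values shown sits. The compound now in question is compound 4 `COc1cc(-n2cnc3ccc(-c4ccc(O)cc4)cc32)cc(OC)c1OC`, which differs from compound 2 in one place: 4-hydroxyphenyl in place of 3-chlorophenyl on an aromatic carbon. Among the compounds with values here, the only measured step is the swap at the same place a 4.2-fold higher number from compound 1 to compound 2 (0.62 log units; beyond the scatter), and that step is modest, so a change of similar size is expected here, plausibly downward toward compound 1. Compound 4 is therefore expected to give 1800 nM in this assay, within a range from 450 nM to 7500 nM, an expected step of a 1.7-fold lower number from compound 2 to compound 4 (0.24 log units; within the scatter).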

Compound 4, half-maximal inhibitory concentration: 4160 nM
The estimate for compound 4 lay 2.3-fold (0.36 log units) below the measured number; low and high end bracket the measured number.
By their numbers in this assay, from the lowest: compound 1; then compounds 2 and 4 (each within the scatter of the next). At a limit, above all of these: compound 3.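

In this assay, the 3-chlorophenyl and 4-hydroxyphenyl groups cannot be told apart at this place on the core (a 1.3-fold higher number from compound 2 to compound 4 (0.12 log units; within the scatter)). The 4-nitrophenyl group of compound 1 now stands apart from two different replacements rather than one, and the swap of hydroxy for nitro shows a clear gap (a 5.6-fold higher number from compound 1 to compound 4 (0.75 log units; beyond the scatter)). Nothing shown here explains that gap. A 4-chlorophenyl group would help separate the effect of the group's place from that of its kind. Where a 4-aminophenyl group or a 4-carboxyphenyl group would fall also stays open.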